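This account rests on a few compounds, and the source may have more. Where it says the series, first, only, none or still open, it means among the compounds named here.

Measured compounds:
Compound 1, `O=C(O)c1cn(-c2ccc(F)cc2)c2nc(N3CCN(C(c4ccccc4)c4ccc(Cl)cc4)CC3)c([N+](=O)[O-])cc2c1=O`: 102000 nM
Compound 2, `CN1CCN(c2nc3c(cc2[N+](=O)[O-])c(=O)c(C(=O)O)cn3-c2ccc(F)cc2)CC1c1ccccc1`: 124000 nM
Compound 3, `CC(C)(C)n1cc(C(=O)O)c(=O)c2cc([N+](=O)[O-])c(N3CCN(C(c4ccccc4)c4ccc(Cl)cc4)CC3)nc21`: > 108000 nM

All three were tested in an ADME assay on Vero cells (Chlorocebus sabaeus) for cytotoxicity, read by MTT assay, with a stated time of 72 h; on this read-out higher numbers stand for weaker inhibition and lower numbers for stronger inhibition. Compound 1 gives 102000 nM and compound 2 gives 124000 nM; the two lie within the scatter of each other, so no order between them is claimed. The value of compound 3 is a limit of the assay, not a number. That compound sits at the limit of > 108000 nM in this assay, at which 1 of the 3 values shown sits. Compound 3 comes from compound 1 by tert-butyl in place of 4-fluorophenyl on an aromatic nitrogen, and the step is an at least 1.0-fold higher number from compound 1 to compound 3 (0.02 log units; that floor lies within the scatter), so only a floor is known for it.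

The core of compound 2 differs from that of compound 1 in a way that is not broken down here.

Compound 4, `CN1CCN(c2nc3c(cc2[N+](=O)[O-])c(=O)c(C(=O)O)cn3C(C)(C)C)CC1c1ccccc1`, has not yet been measured. It comes from compound 2 by tert-butyl in place of 4-fluorophenyl on an aromatic nitrogen, the same change as from compound 1 to compound 3. Set beside the measured step of an at least 1.0-fold higher number from compound 1 to compound 3 (0.02 log units; that floor lies within the scatter), the expected step is a 1.0-fold higher number from compound 2 to compound 4 (0.02 log units; within the scatter). The starting point for this expectation is compound 2 at 124000 nM. For compound 3 only a limit of the assay is known. Compound 4 is therefore estimated to give 130000 nM in this assay, with the expected range running from 70000 nM to 260000 nM, and a real chance that only a limit is reported.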

Compound 4, half-maximal inhibitory concentration: > 134000 nM
Compound 4: no number, only a limit; the forecaster's own chance of this, stated with the estimate: 50%; middle value at least 1.0-fold (0.01 log units) away from the limit.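

In this assay compound 4 gives > 134000 nM, which is a limit of the assay and not a number. With tert-butyl in place of 4-fluorophenyl on the aromatic nitrogen, the result is an at least 1.0-fold higher number from compound 2 to compound 4 (0.03 log units; that floor lies within the scatter), so only a floor is known for the step and its true size stays hidden. Compound 3 and compound 4, the two tert-butyl compounds, both end at a limit of the assay, which shows the change reading alike on the two cores in that one respect but does not show that it carries from one core to the other with the same size: the same change on two cores in this assay, an at least 1.0-fold higher number (0.02 log units; that floor lies within the scatter) from compound 1 to compound 3 and an at least 1.0-fold higher number (0.03 log units; that floor lies within the scatter) from compound 2 to compound 4; the limit leaves it open whether they differ.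

The compounds shown leave open how this assay would read with other groups on the aromatic nitrogen, such as an ethyl or cyclopropyl group or an unsubstituted phenyl, on either core. Going by these compounds, they also leave open what would follow from an amine in place of the nitro group or an ester in place of the carboxylic acid, and the actual numbers behind the limits of compound 3 and compound 4 remain unknown.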